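The source may report more compounds than this note shows. Statements on the series, on what has been measured and on what is new or still open speak of the compounds shown alone.

Compound 1 `COc1ccc(/C=C\C(=O)O[C@@H](C)[C@@H]2CC[C@H]([C@H](O)[C@H]3CC=CC(=O)O3)O2)cc1`: 9500 nM
Compound 2 `C[C@H](OC(=O)/C=C\c1ccc(O)cc1)[C@@H]1CC[C@H]([C@H](O)[C@H]2CC=CC(=O)O2)O1`: 7500 nM
Compound 3 `COc1ccc(/C=C/C(=O)O[C@@H](C)[C@@H]2CC[C@H]([C@H](O)[C@H]3CC=CC(=O)O3)O2)cc1`: 1700 nM

Of the compounds shown here, three have been tested in a functional assay on KB cells (Homo sapiens) for inhibition, read by sulforhodamine B assay, with a stated time of 72 h; on this read-out lower numbers stand for stronger inhibition and higher numbers for weaker inhibition. Compound 1 gives 9500 nM, compound 2 gives 7500 nM and compound 3 gives 1700 nM. Compound 3 thus stands lowest of the three, and its distance from both compound 2 and compound 1 lies beyond the scatter. The step of a 5.6-fold lower number from compound 1 to compound 3 (0.75 log units; beyond the scatter) is attributable only to the configuration of the double bond, because of the fact that compounds 1 and 3 differ only in the configuration as drawn. By contrast, the step of a 1.3-fold lower number from compound 1 to compound 2 (0.10 log units; within the scatter) shows that the change on the aromatic oxygen made little difference within the pair that shares the other double-bond geometry.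

Compound 4 `C[C@H](OC(=O)/C=C/c1ccc(O)cc1)[C@@H]1CC[C@H]([C@H](O)[C@H]2CC=CC(=O)O2)O1` has not yet been measured. It differs from compound 3 by hydrogen in place of methyl on an oxygen on an aromatic ring. Within the data shown here, the only measured step that bears on this change is a 1.3-fold lower number from compound 1 to compound 2 (0.10 log units; within the scatter), which stayed within the scatter. The same outcome is therefore expected here: the step of a 1.2-fold lower number from compound 3 to compound 4 (0.08 log units; within the scatter) is estimated to be small, with perhaps a slight lean toward a lower number. For compound 4 the expected value in this assay is 1400 nM, estimated to fall between 700 nM and 2800 nM.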

Compound 4, half-maximal inhibitory concentration: 3600 nM
Compound 4: the middle estimate sits 2.6-fold (0.41 log units) below what was measured; measured number above the stated range.
By their numbers in this assay, from the lowest: compound 3; then compound 4; then compounds 2 and 1 (each within the scatter of the next).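

In this assay the change from 4-methoxyphenyl to 4-hydroxyphenyl is no longer silent once the double bond is drawn E, with a 2.1-fold higher number from compound 3 to compound 4 (0.33 log units; beyond the scatter), so the outcome of this change at this position depends on the double-bond geometry of the compound that carries it: the same change on two cores in this assay, a 1.3-fold lower number (0.10 log units; within the scatter) from compound 1 to compound 2 and a 2.1-fold higher number (0.33 log units; beyond the scatter) from compound 3 to compound 4, 2.7-fold (0.43 log units) apart, beyond the scatter of two such steps. Among these compounds, the hydroxy pair also gives the first look at geometry without the methyl on the oxygen, and a 2.1-fold lower number from compound 2 to compound 4 (0.32 log units; beyond the scatter) can be put down to the double bond alone: the fact that compounds 2 and 4 differ only in the configuration as drawn. The E form thus has the lower number in both pairs, compound 3 against compound 1 and compound 4 against compound 2, and none of the four compounds goes against this.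

The compounds shown leave open whether a longer chain such as ethyl in place of the methyl on this oxygen, or an amine in place of the hydroxy, would follow compound 3 or compound 4 in this assay. They also leave open whether the dependence on double-bond geometry would hold for such groups, since only methoxy and hydroxy are available here on both geometries.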